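The source may hold more compounds than are shown below. What is called first, only, known or untested is meant among the compounds shown, and "the series" means these compounds.

Measured compounds:
compound 1 `Cc1c(OCCCCOc2ccccc2C(=O)O)ccc(C(=O)CC2CCCC2)c1C` gives 67.1%
compound 2 `COC(=O)c1ccc(OCCCCOc2ccc(C(=O)CC3CCCC3)c(C)c2C)cc1` gives 14.1%
compound 3 `CCC(=O)c1ccc(OCCCCOc2cc(C(=O)O)ccc2OC)c(C)c1O` gives 72.6%

In an assay on HEK293 cells for positive allosteric modulation of metabotropic glutamate receptor 2 (Rattus norvegicus), read by thallium flux, with a stated time of 2.5 min (on this read-out higher numbers stand for larger maximal responses and lower numbers for smaller maximal responses), compound 3 stands highest of the three numbers, although compound 1 lies within the usual scatter of it, so no order between those two can be claimed; compound 2 lies far below both. For the measured compounds named here, the only single-place step among the measured compounds is a number 53 percentage points lower from compound 1 to compound 2 (beyond the scatter), and it concerns a different part of the molecule from the change now considered, so it gives no direct guidance here.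

Compound 4 `COc1ccc(C(=O)O)cc1OCCCCOc1ccc(C(C)=O)c(O)c1C` differs from compound 3 in one place: hydrogen in place of methyl on a saturated chain carbon bound to a carbonyl carbon. Going by the values given here, no measured pair shows the effect of this change, so the expectation for compound 4 rests on compound 3 alone. With nothing to suggest otherwise, compound 4 is expected to stay close to compound 3, meaning a step of a number 4.6 percentage points lower from compound 3 to compound 4 (within the scatter), within the scatter. The estimate for compound 4 in this assay is therefore 68%, with a likely range from 45% to 85%.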

Compound 4, largest response reached (reported as percent of maximum), in percent of the reference or control that the assay uses: 70.7%
Estimate against measurement, compound 4: 2.7 percentage points below; measured number inside the range.
By their numbers in this assay, from the lowest: compound 2; then compounds 1, 4 and 3 (each within the scatter of the next).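

In this assay the change from propanoyl to acetyl comes to a number 1.9 percentage points lower from compound 3 to compound 4 (within the scatter), so the two numbers cannot be told apart. For the compounds shown here, this is the only measured pair that tests this place, a saturated chain carbon bound to a carbonyl carbon, and it shows that the methyl there, a single carbon, is not needed to keep the response at the level of compound 3. Nothing measured here explains this outcome.

Still open, from the compounds shown here alone, is whether a longer chain than propanoyl, or an amine on that same carbon, would keep the response at this level. Also open, going by these compounds, is whether hydrogen in place of methyl at this place would give the same result on the core of compound 1.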